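Tetrazole for nitrile on the ether chain of compound 2

This account rests on a few compounds, and the source may have more. Where it says the series, first, only, none or still open, it means among the compounds named here.

Measured in an assay on isolated protein for binding affinity to leukotriene B4 receptor 1 (Homo sapiens), tested at 1 uM; a lower number here means less inhibition, a higher number more inhibition at the concentration tested (going by the name of the read-out):
compound 1 `C=CCc1cc(C(C)=O)c(O)cc1OCCCCCCCCCCC#N` gives 14%
compound 2 `CCc1cc(C(C)=O)c(O)cc1OCCCCCC(C)(C)C#N` gives 53%
compound 3 `CC(=O)c1cc(C(C)(C)C)c(OCCCCCC(C)(C)C#N)cc1O` gives 2%

Compound 2 stands highest of the three; compound 1 and compound 3 both lie beyond the scatter below it. Compound 4 `CCc1cc(C(C)=O)c(O)cc1OCCCC(C)(C)c1nnn[nH]1` differs from compound 2 in one place: 1-(1H-tetrazol-5-yl)-1-methylethyl in place of 3-cyano-3-methylbutyl on a saturated chain carbon, three bonds along the chain from an oxygen on an aromatic ring.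

Among the measured compounds shown here, the only single step measured is a number 51 percentage points lower from compound 2 to compound 3 (beyond the scatter), a change of the aromatic substituent, not of the chain end, so it does not bear on this change. For the measured compounds named here, compound 1 and compound 2 differ in two places and give no single step either. Nothing measured matches an exchange at the chain end, so the estimate for compound 4 is wide. Compound 4 is expected at 35%, range 5% to 70%. The expected step is a number 18 percentage points lower from compound 2 to compound 4 (beyond the scatter).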

Compound 4, a percentage reported as inhibition, at one concentration (the size of the read-out at that concentration, not a potency): 76%
Compound 4: the middle estimate sits 41 percentage points below what was measured; measured number outside the range, above it.
By their numbers in this assay, from the lowest: compound 3; then compound 1; then compound 2; then compound 4.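

In this assay the exchange of 3-cyano-3-methylbutyl for 1-(1H-tetrazol-5-yl)-1-methylethyl gives a number 23 percentage points higher from compound 2 to compound 4 (beyond the scatter), so the chain end is a place where a single change can raise the read-out. The names show that the stretch of chain and the end group change together, and this one step cannot separate the two. No available evidence accounts for this step.

Open, going by these compounds, is whether a carboxylic acid at the same chain end would give a similar number. Also open, on these data alone, is how the tetrazole would fare on a longer chain.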